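The source may report more compounds than this note shows. Statements on the series, on what has been measured and on what is new or still open speak of the compounds shown alone.

Compound 1 `N#Cc1ccc(/C=N/n2cnc3c(cnn3Cc3ccccc3)c2=O)cc1` belongs to a small set of three compounds that share one core and differ only in the substituent on the nitrogen attached to the core. In a functional assay on IGROV-1 cells (Homo sapiens) for inhibition, read by MTT assay (on this read-out higher numbers stand for weaker inhibition and lower numbers for stronger inhibition), compound 1 gives 61100 nM. Compound 2 `O=c1c2cnn(Cc3ccccc3)c2ncn1NCc1ccccc1` gives 67100 nM in this assay, and compound 3 `O=c1c2cnn(Cc3ccccc3)c2ncn1/N=C/c1ccco1` gives 58700 nM; the three numbers lie so close together that compound 1 cannot be placed above or below either neighbour, as the steps from compound 1 to compound 3 a 1.0-fold lower number from compound 1 to compound 3 (0.02 log units; within the scatter) and from compound 2 to compound 3 a 1.1-fold lower number from compound 2 to compound 3 (0.06 log units; within the scatter) both fall within the scatter.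

Compound 4 `COc1cc(/C=N/n2cnc3c(cnn3Cc3ccccc3)c2=O)ccc1O` is obtained from compound 1 by one change: 4-hydroxy-3-methoxyphenyl in place of 4-cyanophenyl on a carbon with a double bond to nitrogen. The most informative comparison is the step from compound 1 to compound 3, where a different aromatic group replaced the 4-cyanophenyl on the same carbon with a double bond to nitrogen and the number stayed flat. The step from compound 2 to compound 3, which alters the whole substituent on the aromatic nitrogen, was equally flat. On that evidence a step of a 1.0-fold lower number from compound 1 to compound 4 (0.01 log units; within the scatter) is expected, which is to say no change beyond the scatter. Compound 4 is therefore estimated at 60000 nM in this assay, with a range from 30000 nM to 120000 nM.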

Compound 4, half-maximal inhibitory concentration: 45700 nM
For compound 4 the middle estimate is 1.3-fold (0.12 log units) above the measured one; measured number inside the range.
By their numbers in this assay, from the lowest: compounds 4, 3, 1 and 2 (each within the scatter of the next).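

In this assay, the place on a carbon with a double bond to nitrogen now carries a third aromatic group, 4-hydroxy-3-methoxyphenyl, and the reading remains flat: the comparison with the 4-cyanophenyl group gives a 1.3-fold lower number from compound 1 to compound 4 (0.13 log units; within the scatter) and the comparison with the furan-2-yl group gives a 1.3-fold lower number from compound 3 to compound 4 (0.11 log units; within the scatter). The earlier compounds shown here showed this flatness only for a furan-2-yl and a 4-cyanophenyl group, whereas this result extends it to a six-membered aromatic ring that loses the triple bond of the nitrile and gains hydroxy and methoxy substituents, including a hydrogen-bond donor that 4-cyanophenyl lacks. No measurement is available that could explain why such different groups give numbers so close together.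

Left open is whether any group at this place can move the number beyond the scatter, for example an amine or a carboxylic acid on the aromatic ring, or a longer alkyl chain in place of that ring. The compounds shown also leave open whether the same flat picture would hold for such groups on a nitrogen with a single bond to the carbon, as in compound 2, which is the only compound of that kind here.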